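A few compounds are considered here, and "the series" means these few. Any claim that something is new, unique, unknown or untested is made for them only; others in the source may bear on it.

Measured compounds:
- compound 1, `CCCCCCCCOc1nc(N)nc2c1ncn2/C=C1/CC1(CO)CO` — > 300000 nM
- compound 2, `CCCNc1nc(N)nc2c1ncn2/C=C1/CC1(CO)CO` — > 300000 nM

Compound 1 was tested in an ADME assay on HFF cells (Homo sapiens) for cytotoxicity, with a stated time of 8 days; a lower number here means that less compound is tolerated, a higher number that more compound is tolerated. There compound 1 reaches only a limit of the assay, > 300000 nM, so no number is known for it, only that its toxicity lies beyond what the assay can measure. Compound 2 sits at the same limit, > 300000 nM. The step that the two limits leave unreadable from compound 1 to compound 2 therefore cannot be read, because both values rest on (the limit of > 300000 nM in this assay, at which 2 of the 2 values shown sit).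

Going by the values given here, compound 3, `CCCOc1nc(N)nc2c1ncn2/C=C1/CC1(CO)CO`, differs from compound 1 by hydrogen in place of pentyl on a saturated chain carbon, three bonds along the chain from an oxygen on an aromatic ring Of the measured steps, only the one from compound 1 to compound 2 is recorded, and it carries no readable size, so nothing in this set speaks for a change beyond the scatter. With both known compounds resting at the limit of > 300000 nM in this assay, at which 2 of the 2 values shown sit, the most natural expectation is that compound 3 stays at the limit as well, with a step that the limit leaves unreadable from compound 1 to compound 3 expected rather than any movement that the assay could resolve. Compound 3 is thus estimated at 400000 nM, within 150000 nM to 1500000 nM.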

Compound 3, half-maximal cytotoxic concentration: > 300000 nM
Compound 3 gave a limit, no number; the forecaster's own chance of this, stated with the estimate: 85%; the middle value is on the limit's open side.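

In this assay compound 3 gives > 300000 nM, which is a limit of the assay and not a number. No step among compound 1, compound 2 and compound 3 can be read, because all three values rest on the same bound: the limit of > 300000 nM in this assay, at which 3 of the 3 values shown sit.

The compounds shown leave open what concentration of each would harm these cells, and whether octyloxy, propoxy and propylamino differ in this respect at all.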